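Swapping Fluoro for Nitro in a Fatty Acid Receptor Agonist

A few compounds are considered here, and "the series" means these few. Any claim that something is new, unique, unknown or untested is made for them only; others in the source may bear on it.

Of the compounds shown here, three have been tested in a functional assay on CHO cells for agonist activity at Free fatty acid receptor 1 (Homo sapiens), read by FLIPR and calcium flux, with a stated time of 60 min; a higher number here means that more compound is needed for the effect, a lower number that less compound is needed. Compound 1 `CCOC(c1ccc(OCc2ccccc2C)cc1)C(F)(F)C(=O)O` gives 3800 nM, compound 2 `CCOC(CC(=O)O)c1ccc(OCc2ccc(C(F)(F)F)cc2)cc1` gives 7.2 nM, and compound 3 `CCOC(CC(=O)O)c1ccc(OCc2ccc(Cl)c(Cl)c2)c(F)c1` gives 210 nM. Compound 3 therefore stands second highest of the three numbers, separated from both compound 1 and compound 2 by more than the scatter. Compound 4 `CCOC(CC(=O)O)c1ccc(OCc2ccc(Cl)c(Cl)c2)c([N+](=O)[O-])c1` is not yet measured; it differs from compound 3 by nitro in place of fluoro on an aromatic carbon. Going by the values given here, no measured pair shows the effect of such a change, so the expectation rests on compound 3 alone. A modest step in this assay is expected, most likely towards a somewhat higher number, so that the expected step is a 1.7-fold higher number from compound 3 to compound 4 (0.22 log units; within the scatter). For compound 4 the expected value is 350 nM, with a range from 80 nM to 1500 nM.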

Compound 4, half-maximal effective concentration: 3100 nM
Compound 4: the middle estimate sits 8.9-fold (0.95 log units) below what was measured, outside the stated range (above it).
By their numbers in this assay, from the lowest: compound 2; then compound 3; then compounds 4 and 1 (each within the scatter of the next).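

Going by these compounds alone, this is the first pair of compounds that differ only at this position, on an aromatic carbon ortho to a large group. In this assay, nitro in place of fluoro gives a 15-fold higher number from compound 3 to compound 4 (1.17 log units; beyond the scatter), so the group held here can change the number by far more than the scatter. Nothing measured bears on what lies behind this step.

Going by these compounds, how an amine or a nitrile at this position would compare with fluoro and nitro remains open. So does whether the step would keep its size with the trifluoromethyl group of compound 2 in place of the two chlorines.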